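This account rests on a few compounds, and the source may have more. Where it says the series, first, only, none or still open, it means among the compounds named here.

Of the compounds shown here, three that share one core have so far been tested in a functional assay on the whole organism (strain Swiss) with Mus musculus as the target, in the maximal electroshock model, with a stated time of 2 h, at a dose of 300 mg/kg by the intraperitoneal route; on this read-out higher numbers stand for a stronger effect at the one dose given and lower numbers for a weaker effect. Compound 1 `CC(C(=O)N1CCN(c2ccc(Cl)cc2)CC1)N1C(=O)CCC1=O` gives 0% there. Compound 3 `CCC(C(=O)N1CCOCC1)N1C(=O)CCC1=O` gives 0%, the same figure at the digits shown, and these two stand together at the bottom of the set. Compound 2 `CCC(C(=O)N1CCN(c2cccc(C(F)(F)F)c2)CC1)N1C(=O)CCC1=O` gives 50%, a number well beyond the usual scatter above compound 1; compound 2, however, differs from compound 1 in more than one place, so no single part of its structure can be credited with that gap.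

Compound 4 `Cc1cccc(N2CCN(C(=O)C(C)N3C(=O)CCC3=O)CC2)c1` has not yet been measured. It departs from compound 1 by 3-methylphenyl in place of 4-chlorophenyl on an amine nitrogen in a ring. Among the compounds with values here, no pair of measured compounds isolates this one exchange, so the direction of its effect is open. Because compound 1 gives 0% and compound 3 gives 0%, while only compound 2 with several changes at once reaches a higher number, the expected step is a small rise, a number 20 percentage points higher from compound 1 to compound 4 (beyond the scatter), which may not stand out from the scatter. Compound 4 is therefore estimated to show 20%, with a plausible range from 0% to 55%.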

Compound 4, a percentage reported as activity, at one dose (the size of the read-out at that dose, not a potency): 0%
Compound 4: the middle estimate sits 20 percentage points above what was measured; measured number inside the range.
By their numbers in this assay, from the lowest: compounds 1, 3 and 4 (each within the scatter of the next); then compound 2.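

In this assay, within the data shown here, the exchange of 4-chlorophenyl for 3-methylphenyl on the amine nitrogen in the ring gives no change at the digits printed from compound 1 to compound 4 (within the scatter), the first step in this set that isolates a single change. The two groups have the same count of heavy atoms and the same carbon-only aromatic ring, and at this one dose the read-out does not separate them, though a single-dose percentage is not a potency and cannot show whether the two would also match at other doses. No measurement at hand explains this result.

The compounds shown leave open whether the 3-trifluoromethylphenyl group of compound 2 would lift the read-out on the core of compound 1, or whether the longer chain of compound 2 is needed as well. They also leave open how a plain phenyl ring or a 4-methoxyphenyl group would behave on the same nitrogen.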